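A few compounds are considered here, and "the series" means these few. Any claim that something is new, unique, unknown or untested is made for them only; others in the source may bear on it.

Compound 1 `O=C(O)CCc1cc2cc(-c3cccc(OC4CCC4)c3)ccc2o1` carries a longer chain on the aromatic carbon next to the ring oxygen and, in a functional assay on isolated protein for agonist activity at Free fatty acid receptor 1 (Homo sapiens), read by HTRF and inositol phosphate accumulation, with a stated time of 60 min (a lower number here means that less compound is needed, a higher number that more compound is needed for the effect), compound 1 gives 2500 nM. Compound 2 `O=C(O)c1cc2cc(-c3cc(OC(F)(F)F)ccc3F)ccc2o1` bears a carboxy group at that aromatic carbon. In this assay compound 2 reaches only a limit, > 9950 nM, and so stands at the limit of > 9950 nM in this assay, at which 1 of the 2 values shown sits. Compound 3 `Fc1ccc(OC(F)(F)F)cc1-c1ccc2oc(CCc3nn[nH]n3)cc2c1` differs from compound 2 by 2-(2H-tetrazol-5-yl)ethyl in place of carboxy on an aromatic carbon. Among the measured compounds shown here, no measured step between two compounds is available here, yet compound 1, at 2500 nM, shows that a longer chain at this carbon can reach a measurable value. The step from compound 2 to compound 3 is therefore expected to bring a gain, an at least 2.4-fold lower number from compound 2 to compound 3 (0.39 log units; beyond the scatter). Compound 3 is estimated at 4000 nM, within 1000 nM to 15000 nM.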

Compound 3, half-maximal effective concentration: > 9950 nM
Compound 3 gave a limit, no number (the forecaster's own chance of this, stated with the estimate: 30%); middle value at least 2.4-fold (0.39 log units) away from the limit.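

In this assay compound 2 and compound 3 each give only a limit, and the step between them cannot be read. The compounds shown leave open whether 2-(2H-tetrazol-5-yl)ethyl in place of carboxy changes the value at all.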